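Swapping difluoromethoxy for chloro on two related cores

The compounds below may be only part of what the source reports. "The series", "measured", "known", "first", "only" and "open" are said of these compounds alone.

Of the compounds shown here, three have been measured in an assay on IMR-32 cells for displacement of a labelled ligand from corticotropin-releasing factor receptor 1 (Homo sapiens), read by scintillation counting, with a stated time of 2 h; a lower number here means a stronger inhibitor, a higher number a weaker inhibitor. Compound 1 `CCc1nc(-c2ccc(OC(F)F)cc2Cl)c(OC)nc1NC(CC)CC` gives 2.5 nM. Compound 3 `CCc1nc(-c2ccc(Cl)cc2Cl)c(OC)nc1NC(CC)CC` gives 8 nM. Compound 2 `CCC(CC)Nc1nc(C)c(-c2ccc(OC(F)F)cc2Cl)nc1OC` gives 4.6 nM; its number sits between those of the other two, but the gap to each of them lies within the usual scatter of this measurement, so no order among the three is claimed.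

Compound 1 and compound 3 share a core and differ in one place: chloro in place of difluoromethoxy on an aromatic carbon. In this assay this change gave a 3.2-fold higher number from compound 1 to compound 3 (0.51 log units; beyond the scatter), a loss of binding that is modest but beyond the scatter.

Compound 4 `CCC(CC)Nc1nc(C)c(-c2ccc(Cl)cc2Cl)nc1OC` has not yet been measured. It differs from compound 2 in one place: chloro in place of difluoromethoxy on an aromatic carbon. The change is the same as that from compound 1 to compound 3, and the surroundings of the changed position are described in the same words for both pairs. The core of compound 2 is not the core of compound 1, and the difference between the two cores is not broken down here.

For the measured compounds named here, on the one measured example, compound 4 is expected to show a step of about a 3.0-fold higher number from compound 2 to compound 4 (0.48 log units; beyond the scatter) in this assay relative to compound 2, because the matching change gave a 3.2-fold higher number from compound 1 to compound 3 (0.51 log units; beyond the scatter). Compound 4 is therefore estimated at 14 nM, with a likely range from 5 nM to 40 nM.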

Compound 4, inhibition constant: 4.3 nM
Beside the measured number, compound 4's estimate is 3.3-fold (0.51 log units) above it, outside the stated range (below it).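

In this assay, putting chloro in place of difluoromethoxy on the core of compound 2 gives a 1.1-fold lower number from compound 2 to compound 4 (0.03 log units; within the scatter), so on this core the two compounds cannot be told apart, whereas on the core of compound 1 the same swap lost binding. Set side by side, the two steps disagree by more than the usual spread of repeated measurements can explain: the same change on two cores in this assay, a 3.2-fold higher number (0.51 log units; beyond the scatter) from compound 1 to compound 3 and a 1.1-fold lower number (0.03 log units; within the scatter) from compound 2 to compound 4, 3.4-fold (0.53 log units) apart, beyond the scatter of two such steps This shows that the effect of this swap did not carry over from one core to the other in this series, but with only one pair on each core, it does not show why the outcome differs or predict what the swap would do on a further core.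

The compounds shown carry only difluoromethoxy or chloro at this place, so it stays open how a different group, such as trifluoromethyl or a nitrile, would behave on each of the two cores. It also stays open which part of the difference between the two cores matters, as no compound shown separates that difference into single changes.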